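Methoxy to fluoro: a step expected to stay small

A few compounds are considered here, and "the series" means these few. Any claim that something is new, unique, unknown or untested is made for them only; others in the source may bear on it.

Three compounds have been tested in a functional assay on A-375 cells (Homo sapiens) for inhibition, read by CCK-8 assay, with a stated time of 72 h, tested at 2 uM; a lower number here means less inhibition of growth, a higher number more inhibition of growth at the concentration tested:

compound 1 `Nc1ccccc1NC(=O)c1ccc(CSc2ccc(C(F)(F)F)cn2)cc1` gives 4.3%
compound 2 `COc1ccc(SCc2ccc(C(=O)Nc3ccccc3N)cc2)cc1` gives 10.2%
compound 3 `Nc1ccccc1NC(=O)/C=C/c1ccc(CSc2cccc3ccccc23)cc1` gives 1.55%

Compound 2 has the highest of the three numbers, yet its gaps to compound 1 and to compound 3 both fall within the usual scatter of repeated measurements, so no ranking among the three can be read from them. All three sit at low inhibition of growth.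

Compound 4 `Nc1ccccc1NC(=O)c1ccc(CSc2ccc(F)cc2)cc1` differs from compound 2 in one place: fluoro in place of methoxy on an aromatic carbon. Within the data shown here, no pair of measured compounds shares this change, so there is no measured step to lean on. The expectation rests on compound 2 alone, whose value of 10.2% sits low and close to the other two. The step from compound 2 to compound 4 is therefore expected to be a number 3.2 percentage points lower from compound 2 to compound 4 (within the scatter), which is not beyond the scatter in either direction. Compound 4 is expected to give 7%, within a range from 0% to 18%.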

Compound 4, percent growth inhibition at one concentration: 19.4%
Compound 4: middle estimate off by 12.4 percentage points, on the low side; the whole stated range lies below it.
By their numbers in this assay, from the lowest: compounds 3, 1, 2 and 4 (each within the scatter of the next, the first and the last beyond it).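

In this assay, replacing methoxy with fluoro on an aromatic carbon, para to a large group, gives a number 9.2 percentage points higher from compound 2 to compound 4 (within the scatter). Among these compounds, this is the first measured step at this position, and it shows that the change from 4-methoxyphenyl to 4-fluorophenyl, which removes one hydrogen-bond acceptor and leaves one heavy atom in place of two, does not move the number beyond the usual scatter. Nothing available here accounts for the size of this step.

A single step within the scatter cannot show whether this position matters for inhibition of growth. From the compounds shown here alone, it remains open whether a different group here, such as an amine, a carboxylic acid or a longer chain like butoxy, would give a step beyond the scatter.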